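A few compounds are considered here, and "the series" means these few. Any claim that something is new, unique, unknown or untested is made for them only; others in the source may bear on it.

Working notes on the series, read in a functional assay on HL-60 cells (Homo sapiens) for cytotoxicity, read by ELISA, with a stated time of 2 days; on this read-out lower numbers stand for stronger inhibition and higher numbers for weaker inhibition. Compound 1 (`Oc1cccc(-c2cc(-c3ccccc3)cc(-c3cccs3)n2)c1`) gives 14100 nM and compound 2 (`Oc1cccc(-c2cc(-c3ccccc3)nc(-c3ccccc3)c2)c1`) gives 13500 nM, so these two values lie within the scatter of each other and compound 2 stands level with compound 1. Compound 3 (`Oc1cccc(-c2cc(-c3ccccc3)nc(-c3ccco3)c2)c1`) carries furan-2-yl in place of phenyl on an aromatic carbon. For the measured compounds named here, no step between measured compounds is available as a guide, and no shift beyond the scatter is expected in this assay. The estimated step is a 1.1-fold lower number from compound 2 to compound 3 (0.05 log units; within the scatter). For compound 3 the expected value is 12000 nM, with an estimated range of 5000 nM to 28000 nM.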

Compound 3, half-maximal inhibitory concentration: 24000 nM
Beside the measured number, compound 3's estimate is 2.0-fold (0.30 log units) below it; measured number inside the range.
By their numbers in this assay, from the lowest: compounds 2, 1 and 3 (each within the scatter of the next).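

In this assay the swap of furan-2-yl for phenyl next to the ring nitrogen gives a 1.8-fold higher number from compound 2 to compound 3 (0.25 log units; within the scatter), the first step available in this series. On this position, then, a five-membered aromatic ring with one oxygen stands level with the six-membered carbon ring. No measurement at hand accounts for the result. From the compounds shown here alone, whether an amine or a carboxylic acid on this carbon would move the number beyond the scatter remains open, as does the effect of a saturated ring such as morpholine there.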